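The source may hold more compounds than are shown below. What is called first, only, known or untested is meant among the compounds shown, and "the series" means these compounds.

Measured so far in an ADME assay on RAW264.7 cells (Mus musculus) for cytotoxicity, read by MTT assay, with a stated time of 48 h; a higher number here means a weaker inhibitor, a lower number a stronger inhibitor:
- compound 1 `Cc1cc(NC(=O)c2ccc(Cl)c([N+](=O)[O-])c2)ccc1NS(=O)(=O)C(F)(F)F`: 89800 nM
- compound 2 `COc1cc(NC(=O)c2ccc(Cl)c([N+](=O)[O-])c2)ccc1NS(C)(=O)=O`: a limit of the assay, > 250000 nM
- compound 3 `CCS(=O)(=O)Nc1ccc(NC(=O)c2ccc(Cl)c([N+](=O)[O-])c2)cc1OC`: 5660 nM

Compound 3 has the lowest number of the two measured here; compound 1 sits well above it, and compound 2 gives only a limit (the limit of > 250000 nM in this assay, at which 1 of the 3 values shown sits). For the measured compounds named here, the one measured step, an at least 44-fold lower number from compound 2 to compound 3 (1.64 log units; beyond the scatter), is large and goes downward. Compound 4 `COc1cc(NC(=O)c2ccc(Cl)c([N+](=O)[O-])c2)ccc1NS(=O)(=O)C(F)(F)F` differs from compound 3 by trifluoromethyl in place of ethyl on a sulfonyl sulfur. Going by the values given here, no measured step covers an ethyl to trifluoromethyl change on this sulfur; the nearest reference is compound 1, which carries the trifluoromethyl and gives 89800 nM on a methyl rather than methoxy core. The step of a 5.3-fold higher number from compound 3 to compound 4 (0.72 log units; beyond the scatter) is therefore expected upward. Compound 4 is estimated at 30000 nM, between 6000 nM and 150000 nM.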

Compound 4, half-maximal inhibitory concentration: > 250000 nM
Compound 4: no number, only a limit; the forecaster's own chance of this, stated with the estimate: 10%; middle value at least 8.3-fold (0.92 log units) from the limit.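

On the sulfonyl sulfur, trifluoromethyl in place of ethyl reverses the low number of compound 3 in this assay: an at least 44-fold higher number from compound 3 to compound 4 (1.64 log units; beyond the scatter), a step read against a limit. With trifluoromethyl held on the sulfur, methoxy in place of methyl on an aromatic carbon also raises the number, an at least 2.7-fold higher number from compound 1 to compound 4 (0.44 log units; beyond the scatter), so on the shared core only ethyl, in compound 3, gives a measured number. The step from compound 2 to compound 4 cannot be read because both values are limits: the limit of > 250000 nM in this assay, at which 2 of the 4 values shown sit.

From the compounds shown here alone, it remains open whether a propyl or longer chain on the sulfonyl sulfur lowers the number further than ethyl. Going by these compounds, the effect of ethyl on the core of compound 1 also remains open.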